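Compound 2 to compound 3: a change on the side chain

The compounds below may be only part of what the source reports. "The series", "measured", "known", "first", "only" and "open" are said of these compounds alone.

Measured in a functional assay on RS4-11 cells (Homo sapiens) for inhibition, read by CCK-8 assay, with a stated time of 72 h; on this read-out higher numbers stand for weaker inhibition and lower numbers for stronger inhibition:
- compound 1 `CC1(C)CCC(CN2CCN(c3ccc(C(=O)NS(=O)(=O)c4ccc(NCC5CCOCC5)c([N+](=O)[O-])c4)c(Oc4cnc5[nH]ccc5c4)c3)CC2)=C(c2ccc(C(F)(F)F)cc2)C1`: 6.2 nM
- compound 2 `CN1CCC(CNc2ccc(S(=O)(=O)NC(=O)c3ccc(N4CCN(CC5=C(c6ccc(C(F)(F)F)cc6)CC(C)(C)CC5)CC4)cc3Oc3cnc4[nH]ccc4c3)cc2[N+](=O)[O-])C1`: 8.3 nM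

Within the data shown here, only one measured step bears on the place that changes next. There, 1-methylpyrrolidin-3-yl stands in place of oxan-4-yl, and the step is a 1.3-fold higher number from compound 1 to compound 2 (0.13 log units; within the scatter). Among the measured compounds shown here, compound 2 therefore stands within the scatter of the only other measured value.

The unmeasured compound 3 `CC(C)C(=O)N1CCC(CNc2ccc(S(=O)(=O)NC(=O)c3ccc(N4CCN(CC5=C(c6ccc(C(F)(F)F)cc6)CC(C)(C)CC5)CC4)cc3Oc3cnc4[nH]ccc4c3)cc2[N+](=O)[O-])CC1` carries 1-(isopropylcarbonyl)piperidin-4-yl in place of 1-methylpyrrolidin-3-yl on a saturated chain carbon bound to a nitrogen on an aromatic ring.

For the measured compounds named here, no measured compound carries the entering group, so a single small step at this place is a thin guide and the range has to stay wide. No step beyond the scatter is expected in this assay, and no direction is favoured. This expectation starts from compound 2 at 8.3 nM. The expected size of the change is a 1.1-fold higher number from compound 2 to compound 3 (0.04 log units; within the scatter). For compound 3 the estimated value is 9 nM. The expected range for compound 3 runs from 3 nM to 30 nM.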

Compound 3, half-maximal inhibitory concentration: 5.3 nM
For compound 3 the middle estimate is 1.7-fold (0.23 log units) above the measured one; low and high end bracket the measured number.
By their numbers in this assay, from the lowest: compounds 3, 1 and 2 (each within the scatter of the next).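

Notes on the side chain: in this assay, 1-(isopropylcarbonyl)piperidin-4-yl, with 11 heavy atoms against 6 in 1-methylpyrrolidin-3-yl, gives a 1.6-fold lower number from compound 2 to compound 3 (0.19 log units; within the scatter), so a step within the scatter holds at this place on a saturated chain carbon bound to a nitrogen on an aromatic ring even for a group carrying a carbonyl and an isopropyl. Set against oxan-4-yl, the same group gives a 1.2-fold lower number from compound 1 to compound 3 (0.07 log units; within the scatter), so the three groups shown, differing in ring size and in the atoms they carry, stand within the scatter of one another and set no order at this place. No supporting data are at hand to say why these three groups read alike.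

Ring size and the group on the ring nitrogen change together from compound 2 to compound 3, so a 1-methylpiperidin-4-yl group would be needed to separate the two changes. Going by these compounds, it also stays open whether a group of another kind at this place, such as a carboxylic acid, a primary amine or a longer chain, would give a step beyond the scatter.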